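The source may hold more compounds than are shown below. What is called first, only, known or untested is meant among the compounds shown, and "the series" means these compounds.

Measured so far:
compound 1 `Cc1ccc(Cn2nnc(-c3cc([N+](=O)[O-])cc([N+](=O)[O-])c3)n2)cc1` gives 200000 nM
compound 2 `O=[N+]([O-])c1cc(-c2nnn(Cc3ccc(Cl)cc3)n2)cc([N+](=O)[O-])c1` gives 170000 nM
compound 3 `O=[N+]([O-])c1cc(-c2nnn(Cc3cccc(Cl)c3)n2)cc([N+](=O)[O-])c1` gives 27000 nM

All three were measured in an ADME assay on CHO-K1 cells (Cricetulus griseus) for cytotoxicity, read by MTT assay, with a stated time of 24 h; on this read-out lower numbers stand for stronger inhibition and higher numbers for weaker inhibition. Compound 3 gives the lowest number of the three: the step of a 6.3-fold lower number from compound 2 to compound 3 (0.80 log units; beyond the scatter) and the step of a 7.4-fold lower number from compound 1 to compound 3 (0.87 log units; beyond the scatter) both lie beyond the scatter, whereas the step of a 1.2-fold lower number from compound 1 to compound 2 (0.07 log units; within the scatter) does not.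

Compound 4 `O=[N+]([O-])c1cc(-c2nnn(Cc3ccccc3F)n2)cc([N+](=O)[O-])c1` has not yet been measured. It differs from compound 3 in one place: 2-fluorophenyl in place of 3-chlorophenyl on a saturated chain carbon bound to an aromatic nitrogen. The two steps that bear on this kind of change, those from compound 1 and from compound 2 to compound 3, were modest, and both ended at compound 3, the compound with the lowest number. For the measured compounds named here, no measured step shows a 2-fluorophenyl group, so the direction for compound 4 is uncertain. Since the two other groups tried at this place gave higher numbers than compound 3, a modest rise is the more likely expectation. For compound 4 the number is estimated as 60000 nM, with a range from 20000 nM to 200000 nM, which is the expected step of a 2.2-fold higher number from compound 3 to compound 4 (0.35 log units; beyond the scatter).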

Compound 4, half-maximal inhibitory concentration: > 200000 nM
Compound 4: only a limit was reported; the forecaster's own chance of this, stated with the estimate: 10%; middle value at least 3.3-fold (0.52 log units) from the limit.
By their numbers in this assay, from the lowest: compound 3; then compounds 2 and 1 (each within the scatter of the next).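

Compound 4 is reported in this assay only as a limit: the limit of > 200000 nM in this assay, at which 1 of the 4 values shown sits.

The change to 2-fluorophenyl brings an at least 7.4-fold higher number from compound 3 to compound 4 (0.86 log units; beyond the scatter), so a third group at this place now stands clearly apart from compound 3, and among the four compounds the low number belongs to the 3-chlorophenyl group alone. Against the 4-chlorophenyl group the result is less firm: it brings an at least 1.1-fold higher number from compound 2 to compound 4 (0.07 log units; that floor lies within the scatter), and the change from the 4-methylphenyl group brings a number no lower from compound 1 to compound 4 (the limit leaves the size open), so compound 4 cannot be ordered against compounds 1 and 2.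

On these data alone, how far the true number of compound 4 lies past its limit stays open. Also open, as far as these compounds go, is how a plain phenyl group, or a longer chain between the ring and the aromatic nitrogen, would read in this assay.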